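Methyl in Place of Methoxy: Compound 3 to Compound 4

The compounds below may be only part of what the source reports. "The series", "measured", "known", "first", "only" and "open" are said of these compounds alone.

Three compounds sharing one core were tested in an assay on isolated protein for inhibition of extracellular serine/threonine protein kinase FAM20C (Homo sapiens), read by malachite green, tested at 10 uM, in the presence of a further agent that is not named here; on this read-out lower numbers stand for less inhibition and higher numbers for more inhibition at the one concentration tested (going by the name of the read-out). Compound 1 `Cc1cc(Nc2ccc(F)cc2)nc(Nc2ccc(NS(=O)(=O)c3ccccc3OC(F)(F)F)cc2)n1` gives 23%. Compound 2 `COc1ccc(Nc2cc(C)nc(Nc3ccc(NS(=O)(=O)c4c(Cl)cc(C)cc4OC)cc3)n2)cc1` gives 12%. Compound 3 `COc1ccc(Nc2ccnc(Nc3ccc(NS(=O)(=O)c4ccc(OC)cc4)cc3)n2)cc1` gives 25%, the highest of the three numbers; the number for compound 1 lies within the scatter of it, while the number for compound 2 lies beyond the scatter below it.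

Compound 4 `COc1ccc(Nc2ccnc(Nc3ccc(NS(=O)(=O)c4ccc(C)cc4)cc3)n2)cc1` has not yet been measured. It differs from compound 3 by methyl in place of methoxy on an aromatic carbon, a small change at the outer edge of the molecule. Among the measured compounds shown here, with no measured step of this kind available, the step from compound 3 to compound 4 is expected to be small, with no clear direction beyond the scatter, as a number 3 percentage points lower from compound 3 to compound 4 (within the scatter). Compound 4 is therefore estimated at 22%, within the range 8% to 38%.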

Compound 4, a percentage reported as inhibition, at one concentration (the size of the read-out at that concentration, not a potency): 28%
For compound 4 the middle estimate is 6 percentage points below the measured one; the measured number falls inside the stated range.
By their numbers in this assay, from the lowest: compound 2; then compounds 1, 3 and 4 (each within the scatter of the next).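

In this assay, among the compounds shown here, the step of a number 3 percentage points higher from compound 3 to compound 4 (within the scatter) is the first measured at this position, on the aromatic carbon para to a large group. Going from 4-methoxyphenyl to 4-methylphenyl removes the oxygen and one hydrogen-bond acceptor, yet the number stays within the scatter. Going by these compounds, whether an amine, a carboxylic acid or a longer chain at this place would move the number beyond the scatter remains open, as does whether the same change behaves alike on other members. Nothing measured here explains the size of this step.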